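From Methyl to Propoxy: Expecting the Next Cytotoxicity Value

This account rests on a few compounds, and the source may have more. Where it says the series, first, only, none or still open, it means among the compounds named here.

Of the compounds shown here, three sharing one core have been tested in a functional assay on A549 cells (Homo sapiens) for cytotoxicity, with a stated time of 48 h; on this read-out higher numbers stand for weaker inhibition and lower numbers for stronger inhibition. Compound 1 `Cc1cccc2c(=O)cc(/C=C/[S+](C)[O-])oc12` gives 1700 nM. Compound 2 `Cc1ccc2oc(/C=C/[S+](C)[O-])cc(=O)c2c1` gives 1700 nM, level with compound 1 at the digits shown, and together these two are the lowest of the three numbers. Compound 3 `COc1cccc2oc(/C=C/[S+](C)[O-])cc(=O)c12` gives 3800 nM, a number that lies beyond the scatter from compound 2. The next compound, compound 4 `CCCOc1ccc2oc(/C=C/[S+](C)[O-])cc(=O)c2c1`, has not yet been measured. It differs from compound 2 by propoxy in place of methyl on an aromatic carbon. Among the compounds with values here, no measured pair shows this exact change, so the expected step in this assay is small, perhaps toward a slightly higher number, and may well remain within the scatter. Compound 4 is therefore expected to give about 2500 nM, in a range from 1000 nM to 6000 nM, which would mean a 1.5-fold higher number from compound 2 to compound 4 (0.17 log units; within the scatter).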

Compound 4, half-maximal inhibitory concentration: 1100 nM
For compound 4 the middle estimate is 2.3-fold (0.36 log units) above the measured one, and the stated range covers the measured number.
By their numbers in this assay, from the lowest: compounds 4, 1 and 2 (each within the scatter of the next); then compound 3.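

In this assay putting propoxy in place of methyl on this aromatic carbon gives a 1.5-fold lower number from compound 2 to compound 4 (0.19 log units; within the scatter) and that step lies within the scatter. Within the data shown here, this position therefore carries the bigger propoxy group, with its added oxygen, with no step that stands out from the scatter. Nothing measured here explains this result.

Going by these compounds, whether a longer chain, an amine or a carboxylic acid on this carbon would also stay within the scatter of compound 2 remains open. So does whether propoxy would give a similar step elsewhere on the shared core.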